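Swapping One Five-Membered Ring for Another

A few compounds are considered here, and "the series" means these few. Any claim that something is new, unique, unknown or untested is made for them only; others in the source may bear on it.

Compound 1 `Cc1nc(N2CCC(N3C(=O)CCC3=O)CC2)nc2ccc(NC(=O)/C=C/c3ccc(OC(F)(F)F)cc3)cc12` and compound 2 `Cc1nc(NCCNS(C)(=O)=O)nc2ccc(NC(=O)/C=C/c3ccc(OC(F)(F)F)cc3)cc12` share a core and differ in the group on the other side of it. In an assay on CHO-K1 cells for displacement of a labelled ligand from melanin-concentrating hormone receptor 1 (Homo sapiens), read by scintillation proximity assay, with a stated time of 2 h (on this read-out lower numbers stand for stronger inhibition and higher numbers for weaker inhibition), compound 1 gives 94 nM, and compound 2 gives 169 nM; the two numbers lie within the usual scatter, so neither stands apart. Compound 3 `Cc1nc(N2CCC(N3CCN(C)C3=O)CC2)nc2ccc(NC(=O)/C=C/c3ccc(OC(F)(F)F)cc3)cc12` follows from compound 1 by the change (3-methyl-2-oxoimidazolidin-1-yl in place of 2,5-dioxopyrrolidin-1-yl on a saturated ring carbon). For the measured compounds named here, with only two measured compounds and no measured step of this kind, the expected step from compound 1 to compound 3 is small, no more than the scatter, as a 1.2-fold lower number from compound 1 to compound 3 (0.07 log units; within the scatter) shows. For compound 3 the estimate in this assay is 80 nM, within a range from 30 nM to 250 nM.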

Compound 3, half-maximal inhibitory concentration: 21 nM
The estimate for compound 3 lay 3.8-fold (0.58 log units) above the measured number, outside the stated range (below it).
By their numbers in this assay, from the lowest: compound 3; then compounds 1 and 2 (each within the scatter of the next).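

In this assay, for the compounds shown here, the swap gives a 4.5-fold lower number from compound 1 to compound 3 (0.65 log units; beyond the scatter) and is the first measured step at this saturated ring carbon. It shows that the number responds to the group here, even though both groups have the same heavy-atom count, a five-membered non-aromatic ring and no net charge. Nothing measured here explains the shift. Going by these compounds, it remains open which difference matters: the second ring nitrogen with its methyl or the missing carbonyl. On these data alone, how an amine or a carboxylic acid on this carbon would compare is also open.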